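The source may report more compounds than this note shows. Statements on the series, on what has been measured and on what is new or still open speak of the compounds shown alone.

Compound 1 `c1ccc2c(c1)CN[C@@H](CN(CCCCNCc1ccncc1)[C@H]1CCCc3cccnc31)C2`: > 30000 nM
Compound 2 `c1ccc2c(c1)CN[C@@H](CN(CCCCNCC1CCOCC1)[C@H]1CCCc3cccnc31)C2`: > 30000 nM
Compound 3 `NCc1ccccc1CN(C[C@H]1Cc2ccccc2CN1)[C@H]1CCCc2cccnc21`: > 30000 nM

In a functional assay on cells for agonist activity at C-X-C chemokine receptor type 4 (Homo sapiens), read by fluorescence and calcium flux, with a stated time of 90 s (on this read-out lower numbers stand for an effect already at smaller amounts and higher numbers for an effect only at larger amounts of compound), compound 1 gives only a limit of the assay, > 30000 nM. Compound 2 also gives only a limit, > 30000 nM. Compound 3 likewise gives only a limit, > 30000 nM. Compound 3 thus stands at the same limit as the others, with no number to place it: the limit of > 30000 nM in this assay, at which 3 of the 3 values shown sit. Compound 4 `NCc1cccc(CN(C[C@H]2Cc3ccccc3CN2)[C@H]2CCCc3cccnc32)c1` differs from compound 3 by 3-(aminomethyl)phenyl in place of 2-(aminomethyl)phenyl on a saturated chain carbon bound to an amine nitrogen. For the measured compounds named here, the steps that touch compound 3, a step that the two limits leave unreadable from compound 1 to compound 3 and a step that the two limits leave unreadable from compound 2 to compound 3, cannot be sized, and a step that the two limits leave unreadable from compound 1 to compound 2 is equally unreadable, so no measured step shows how far a change at this position can move the read-out. The expectation is therefore that compound 4 also sits at the limit, and the estimated step is a step that the limit leaves unreadable from compound 3 to compound 4. Compound 4 is estimated at 50000 nM, between 10000 nM and 300000 nM.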

Compound 4, half-maximal effective concentration: > 30000 nM
Compound 4: only a limit was reported; the forecaster's own chance of this, stated with the estimate: 85%; the middle value is on the limit's open side.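

For the compounds shown here, compound 4 gives only a limit, as do compound 1, compound 2 and compound 3, so no step to compound 4 can be read in this assay. The compounds shown leave open whether changing this group moves the read-out at all: the limit of > 30000 nM in this assay, at which 4 of the 4 values shown sit.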